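The source may report more compounds than this note shows. Statements on the series, on what has been measured and on what is new or still open speak of the compounds shown alone.

Three measured compounds share one core and differ only in the group on one aromatic carbon. Compound 1 `C#CCOc1ccc(-c2cc(-c3ccc(OCC#C)cc3)nc(C)n2)cc1` gives 34200 nM in an assay on BTI-TN-5B1-4 cells for inhibition of Amine oxidase [flavin-containing] A (Homo sapiens), read by fluorescence and Amplex Red, using microsomes, with a stated time of 30 min; a lower number here means a stronger inhibitor, a higher number a weaker inhibitor. Compound 2 `C#CCOc1ccc(-c2cc(-c3ccc(OCC#C)cc3)nc(-c3ccccc3)n2)cc1` gives 25600 nM in this assay, and compound 3 `C#CCOc1ccc(-c2cc(-c3ccc(OCC#C)cc3)nc(N)n2)cc1` gives 32100 nM. Compound 2 holds the lowest of the three numbers, yet the steps of a 1.3-fold lower number from compound 1 to compound 2 (0.13 log units; within the scatter) and a 1.3-fold higher number from compound 2 to compound 3 (0.10 log units; within the scatter) are both within the scatter, as is a 1.1-fold lower number from compound 1 to compound 3 (0.03 log units; within the scatter). Compound 4 `C#CCOc1ccc(-c2cc(-c3ccc(OCC#C)c(OC)c3)nc(-c3ccccc3)n2)cc1` differs from compound 2 by methoxy in place of hydrogen on an aromatic carbon. Going by the values given here, none of the measured steps touches that place; all three change the group on the other aromatic carbon, and all stay within the scatter. Compound 4 is therefore expected to show no step beyond the scatter, with a 1.0-fold lower number from compound 2 to compound 4 (0.01 log units; within the scatter). The estimate for compound 4 is 25000 nM, with a range from 10000 nM to 60000 nM.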

Compound 4, half-maximal inhibitory concentration: 24900 nM
Compound 4: the middle estimate sits 1.0-fold (0.00 log units) above what was measured; low and high end bracket the measured number.
By their numbers in this assay, from the lowest: compounds 4, 2, 3 and 1 (each within the scatter of the next).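

Methoxy in place of hydrogen, ortho to a propargyloxy group, gives a 1.0-fold lower number from compound 2 to compound 4 (0.01 log units; within the scatter) in this assay. Going by these compounds alone, the earlier steps changed only the group on another aromatic carbon, so this is the first sign that a second place on the shared core can take a new group without a step beyond the scatter. Nothing available explains this result.

On these data alone, whether an amine, a carboxylic acid or a longer chain at this position would give a step beyond the scatter remains open. So does whether methoxy would behave the same way on the cores of compound 1 and compound 3.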